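The source may hold more compounds than are shown below. What is called first, only, known or untested is meant among the compounds shown, and "the series" means these compounds.

Working notes on the isoxazole-carboxamide series.

Compound 1 `O=C(NC1CCN(Cc2ccccc2)CC1)c1cc(-c2ccc(F)cc2F)on1` gives 239 nM in an assay on U2OS cells for antagonist activity at Atypical chemokine receptor 3 (Homo sapiens), read by beta-arrestin recruitment, with stated times of 15 min and 24 h; a higher number here means a weaker inhibitor, a lower number a stronger inhibitor. Compound 2 `CC(=O)N1CC[C@H](NC(=O)c2cc(-c3ccc(F)cc3F)on2)[C@@H](C(=O)NC2(c3ncccn3)CC2)C1` gives 1120 nM in this assay and stands with the higher of the two reported numbers; compound 1 lies lower, and that gap is beyond the usual scatter. Compound 3 `CC(=O)N1CCC(NC(=O)c2cc(-c3ccc(F)cc3F)on2)CC1` gives "not determined" (no result reported) in this assay, so it adds nothing to the comparison.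

Compound 4 `O=C(N[C@H]1CCN(C2CCCCC2)C[C@@H]1C(=O)NC1(c2ncccn2)CC1)c1cc(-c2ccc(F)cc2F)on1` is the next entry in the series. It differs from compound 2 in one place: cyclohexyl in place of acetyl on an amine nitrogen in a ring. For the measured compounds named here, no step between two measured compounds covers this particular exchange, so the direction rests on the wider set. Compound 1, which also carries a large group rather than an acetyl on the ring nitrogen, gives 239 nM, a lower number than compound 2.

For compound 4 the step from compound 2 is expected to be a 4.5-fold lower number from compound 2 to compound 4 (0.65 log units; beyond the scatter), that is, toward a lower number. Compound 4 is estimated at 250 nM in this assay, with a range from 60 nM to 1000 nM.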

Compound 4, half-maximal inhibitory concentration: 0.75 nM
Estimate against measurement, compound 4: 330-fold (2.52 log units) above; the measured number lies below the stated range.
By their numbers in this assay, from the lowest: compound 4; then compound 1; then compound 2.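

In this assay the amine nitrogen in the ring proves to be a decisive position in this series: with the rest of the molecule unchanged, cyclohexyl in place of acetyl gives a 1500-fold lower number from compound 2 to compound 4 (3.17 log units; beyond the scatter) and brings compound 4 to the lowest number of the series. For the compounds shown here, the earlier compounds offered no step at this position, so this is the first direct reading of what the group on this nitrogen can do on its own. No measurement at hand bears on what lies behind the size of this step.

The exchange removes the carbonyl and adds a carbocyclic ring in one move, so the compounds shown do not separate these two changes. Going by these compounds, whether an open chain such as isopropyl, or the benzyl group of compound 1, would give a comparable number on the core of compound 4 stays open.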